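The source may report more compounds than this note shows. Statements on the series, on what has been measured and on what is new or still open speak of the compounds shown alone.

Measured so far:
- compound 1 `OCC(O)COc1nc(N2CCCCC2)c2nc(OCC(O)CO)nc(N3CCCCC3)c2n1` gives 32%
- compound 2 `CC1(C)OC[C@@H](COc2nc(N3CCCCC3)c3nc(OC[C@@H]4COC(C)(C)O4)nc(N4CCCCC4)c3n2)O1` gives 100%

Of the two measured compounds in a functional assay on L1210 cells (Mus musculus) for inhibition, read by thymidine incorporation, tested at 10 uM (on this read-out higher numbers stand for a stronger effect at the one concentration tested and lower numbers for a weaker effect), compound 1 stands lowest; compound 2 sits a long way higher, beyond the scatter, so the pair does not indicate what a stereochemical refinement alone would do.

The next compound, compound 3 `OCC(O)COc1nc(N2CCCCC2)c2nc(OC[C@@H](O)CO)nc(N3CCCCC3)c2n1`, keeps the whole skeleton of compound 1. Difference: the two compounds have the same atoms and bonds; at least one stereo element is drawn with a configuration in one of them and without one in the other: 1 of 2 stereo elements differ; a stereocentre at a saturated chain carbon is drawn without a configuration in compound 1 and S in compound 3. Compound 3 is therefore a stereodefined form of the material that compound 1 represents, with one stereocentre left as drawn in compound 1.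

Among the compounds with values here, no step between measured compounds bears on such a change. Resolving one centre of two could leave the read-out in this assay where compound 1 lies or shift it moderately in either direction; the expectation is no step beyond the scatter. Compound 3 is estimated at 36%, with a range of 15% to 62%, which corresponds to an expected step of a number 4 percentage points higher from compound 1 to compound 3 (within the scatter).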

Compound 3, a percentage reported as inhibition, at one concentration (the size of the read-out at that concentration, not a potency): 37%
Compound 3: middle estimate off by 1 percentage points, on the low side; the measured number falls inside the stated range.
By their numbers in this assay, from the lowest: compounds 1 and 3 (each within the scatter of the next); then compound 2.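

In this assay, defining one stereocentre at a saturated chain carbon as S, with the other left as drawn, gives a number 5 percentage points higher from compound 1 to compound 3 (within the scatter). Within the data shown here, this is the first one-place comparison, and at this carbon the S drawing and the undefined drawing are not separated on this read-out. The pair rests on a single structural difference: the fact that one of compounds 1 and 3 is drawn with a defined configuration and the other without, at the place where they differ

Still open, from the compounds shown here alone, is whether the R configuration at this carbon, or a defined configuration at the second stereocentre, would read the same way at this single concentration. Among these compounds, also open is how an amine or a carboxylic acid in place of the chain hydroxyl groups would read, since every step so far leaves the atoms and bonds unchanged.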